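Swapping the Amide Substituent in a Weak Antiproliferative Series

This account rests on a few compounds, and the source may have more. Where it says the series, first, only, none or still open, it means among the compounds named here.

Compound 3 `Cc1noc(C)c1-c1nn(Cc2ccc(C(=O)NC3CC3)cc2)c(=O)c2ccccc12` carries a cyclopropylamino group on its carbonyl carbon. In a functional assay on HepG2 cells (Homo sapiens) for antiproliferative activity, read by MTT assay, with a stated time of 72 h (a higher number here means a weaker inhibitor, a lower number a stronger inhibitor), compound 3 gives only a limit, > 100000 nM, not a number. Compound 4 `Cc1noc(C)c1-c1nn(Cc2ccc(C(=O)N3CCCCC3)cc2)c(=O)c2ccccc12` differs from it in one place: piperidin-1-yl in place of cyclopropylamino on a carbonyl carbon. Two relatives carry the same (piperidin-1-yl)carbonyl group on a different shared core: compound 1 `Cn1cc(-c2nn(Cc3ccc(C(=O)N4CCCCC4)cc3)c(=O)c3ccccc23)cn1` and compound 2 `CN1CCC(NC(=O)c2ccc(Cn3nc(-c4cnn(C)c4)c4ccccc4c3=O)cc2)CC1`. In this assay compound 1 gives 73100 nM. Compound 2 gives 47300 nM in this assay. For the measured compounds named here, the only measured step, a 1.5-fold lower number from compound 1 to compound 2 (0.19 log units; within the scatter), concerns a different change and stays within the scatter, so nothing measured bears directly on the swap from compound 3 to compound 4. Because one value already sits at the limit of > 100000 nM in this assay, at which 1 of the 3 values shown sits, compound 4 is expected to remain close to that limit, a step of a number no higher from compound 3 to compound 4 (the limit leaves the size open). Compound 4 is therefore estimated at 100000 nM, between 50000 nM and 200000 nM.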

Compound 4, half-maximal inhibitory concentration: 97300 nM
Compound 4: the middle estimate sits 1.0-fold (0.01 log units) above what was measured, within the range that was stated.
By their numbers in this assay, from the lowest: compounds 2, 1 and 4 (each within the scatter of the next, the first and the last beyond it). At a limit, above all of these: compound 3.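

Compound 3 remains a limit, not a number: the limit of > 100000 nM in this assay, at which 1 of the 4 values shown sits. The swap to piperidin-1-yl can therefore be read only as an at least 1.0-fold lower number from compound 3 to compound 4 (0.01 log units; that floor lies within the scatter), which leaves its true size open. The new comparison on the aromatic carbon, a 1.3-fold higher number from compound 1 to compound 4 (0.12 log units; within the scatter), shows that 3,5-dimethyl-1,2-oxazol-4-yl and 1-methyl-1H-pyrazol-4-yl give values within the scatter of each other when both compounds carry (piperidin-1-yl)carbonyl.

On these data alone, it remains open how (1-methylpiperidin-4-yl)amino would behave on the core of compound 4. As far as these compounds go, it is also open whether a morpholin-4-yl group on the carbonyl carbon, or a carboxylic acid in place of the amide, would give a clearly lower number.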